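Swapping the triazole aryl: hydroxyphenyl to methylphenyl

The source may hold more compounds than are shown below. What is called first, only, known or untested is meant among the compounds shown, and "the series" means these compounds.

Compound 1 `O=C1O[C@H]([C@@H](O)Cn2cc(-c3cccc(O)c3)nn2)C(OCc2ccccc2)=C1OCc1ccccc1`: > 100000 nM
Compound 2 `Cc1ccc(-c2cn(C/C=C3\OC(=O)C(OCc4ccccc4)=C3OCc3ccccc3)nn2)cc1`: > 100000 nM
Compound 3 `O=C1O/C(=C\Cn2cc(-c3cccc(O)c3)nn2)C(OCc2ccccc2)=C1OCc1ccccc1`: 69800 nM

In a functional assay on SW-620 cells (Homo sapiens) for antiproliferative activity, read by MTT assay, with a stated time of 72 h (on this read-out higher numbers stand for weaker inhibition and lower numbers for stronger inhibition), compound 1 gives only a limit, namely > 100000 nM. Compound 2 also stops at a limit in this assay. Among the measured compounds shown here, compound 3 is the one compound with a number, 69800 nM, and the pair share (the limit of > 100000 nM in this assay, at which 2 of the 3 values shown sit). Compound 4 `Cc1ccc(-c2cn(C[C@H](O)[C@H]3OC(=O)C(OCc4ccccc4)=C3OCc3ccccc3)nn2)cc1` differs from compound 1 by 4-methylphenyl in place of 3-hydroxyphenyl on an aromatic carbon. For the measured compounds named here, the one measured step on this change runs the other way: an at least 1.4-fold lower number from compound 2 to compound 3 (0.15 log units; that floor lies within the scatter). Read backwards, it points to a number no lower and possibly higher, so for compound 4 the floor of an at least 1.4-fold lower number from compound 2 to compound 3 (0.15 log units; that floor lies within the scatter) suggests a step that the limit leaves unreadable from compound 1 to compound 4 is expected. Compound 4 is estimated at 150000 nM, within 70000 nM to 400000 nM, most likely reported as a limit.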

Compound 4, half-maximal inhibitory concentration: > 100000 nM
Compound 4 gave a limit, no number; the forecaster's own chance of this, stated with the estimate: 85%; the middle value lies beyond the limit too.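

In this assay compound 4 gives only a limit, > 100000 nM. Compound 1 also stops at a limit, so no step can be read between compound 1 and compound 4. From the compounds shown here alone, what 4-methylphenyl in place of 3-hydroxyphenyl does on this core stays open.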